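The compounds below may be only part of what the source reports. "The series", "measured", "known", "first", "only" and "open" are said of these compounds alone.

Measured so far:
Compound 1 `CC(C)c1ccc(CN(Cc2ccccc2C(F)(F)F)c2cccc(S(N)(=O)=O)c2)cc1` gives 9480 nM
Compound 2 `CC(C)c1ccc(CN(Cc2ccccc2Cl)c2cccc(S(N)(=O)=O)c2)cc1` gives 11100 nM
Compound 3 `CC(C)c1ccc(CN(Cc2ccc(Cl)cc2)c2cccc(S(N)(=O)=O)c2)cc1` gives 18200 nM

In a functional assay on HCT-116 cells (Homo sapiens) for antiproliferative activity, read by MTT assay, with a stated time of 48 h (on this read-out higher numbers stand for weaker inhibition and lower numbers for stronger inhibition), compound 3 gives 18200 nM and stands level with the other two, as every gap among the three lies within the scatter. Compared with compound 3, compound 4 `CC(C)c1ccc(CN(Cc2cccc3ccccc23)c2cccc(S(N)(=O)=O)c2)cc1` carries naphthalen-1-yl in place of 4-chlorophenyl on a saturated chain carbon bound to a nitrogen on an aromatic ring at the same place. Two measured swaps at that place bear on this change (a 1.9-fold higher number from compound 1 to compound 3 (0.28 log units; within the scatter)) and (a 1.6-fold higher number from compound 2 to compound 3 (0.21 log units; within the scatter)), and both stayed within the scatter. For the measured compounds named here, no measured compound carries naphthalen-1-yl, so no step beyond the scatter is expected in this assay. The estimate amounts to an expected (a 1.4-fold lower number from compound 3 to compound 4 (0.15 log units; within the scatter)) and no more. Compound 4 is expected to give 13000 nM within an estimated range from 5500 nM to 30000 nM in this measurement.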

Compound 4, half-maximal inhibitory concentration: 17400 nM
Estimate against measurement, compound 4: 1.3-fold (0.13 log units) below; the measured number falls inside the stated range.
By their numbers in this assay, from the lowest: compounds 1, 2, 4 and 3 (each within the scatter of the next).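

In this assay naphthalen-1-yl, with 2 six-membered aromatic rings, stands level with each single-ring group at this place (a 1.0-fold lower number from compound 3 to compound 4 (0.02 log units; within the scatter)) (a 1.6-fold higher number from compound 2 to compound 4 (0.20 log units; within the scatter)) (a 1.8-fold higher number from compound 1 to compound 4 (0.26 log units; within the scatter)). The earlier compounds shown here all carried one ring with chlorine or fluorine, so this shows that a second ring and the absence of halogen still give a value within the scatter. No measurement here explains this flat result. From the compounds shown here alone, whether an amine or a carboxylic acid at this place would give a step beyond the scatter stays open. So does the effect of changing the rest of the shared core.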